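This account rests on a few compounds, and the source may have more. Where it says the series, first, only, none or still open, it means among the compounds named here.

Three compounds share a core carrying a nitrile-bearing substituent and a pyridine-linked biaryl arm, and all three have been tested in a functional assay on UO-31 cells (Homo sapiens) for cytotoxicity, read by sulforhodamine B assay, with a stated time of 48 h, tested at 0.01 uM; on this read-out lower numbers stand for a stronger effect and higher numbers for a weaker effect at the one concentration tested. Compound 1 `COc1cc(C)cc(-c2nn(CC#N)cc2-c2ccc(-c3cccc(C(C)=O)c3)nc2)c1` gives 86% in this assay. Compound 2 `Cc1cc(O)cc(-c2nn(CC#N)cc2-c2ccnc(-c3ccc(Oc4ccccc4)cc3)c2)c1` gives 85%. Compound 3 `COc1cc(C)cc(-c2nn(CC#N)cc2-c2ccnc(-c3ccc(N(C)C)cc3)c2)c1` gives 92%, the highest number of the three, yet its gaps to compound 1 and to compound 2 both lie within the usual scatter of this assay, so the three numbers cannot be set in order.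

Compound 4 `Cc1cc(O)cc(-c2nn(CC#N)cc2-c2ccnc(-c3ccc(N(C)C)cc3)c2)c1` has not yet been measured. It differs from compound 3 in one place: hydrogen in place of methyl on an oxygen on an aromatic ring. Going by the values given here, no step between measured compounds isolates this change, so nothing measured shows its effect directly. Compound 2, which carries the hydroxy group on a different arm, sits at a number close to that of compound 3, which suggests no step beyond the scatter. Compound 4 is therefore expected to give 89%, within 78% to 98%, an expected step of a number 3 percentage points lower from compound 3 to compound 4 (within the scatter) that stays inside the scatter.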

Compound 4, a percentage reported as activity, at one concentration (the size of the read-out at that concentration, not a potency): 84%
Compound 4: middle estimate off by 5 percentage points, on the high side; the range from low to high includes it.
By their numbers in this assay, from the lowest: compounds 4, 2, 1 and 3 (each within the scatter of the next).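

Going by these compounds alone, the pair of compound 3 and compound 4 gives the first direct reading of methoxy to hydroxy on the 3-methoxy-5-methylphenyl arm. With the dimethylamino group held fixed, this assay shows a number 8 percentage points lower from compound 3 to compound 4 (within the scatter) for this swap, so hydrogen in place of methyl on this oxygen has no readable effect at the one concentration tested. With the hydroxy group held fixed, dimethylamino in place of phenoxy on an aromatic carbon shows a number 1 percentage points lower from compound 2 to compound 4 (within the scatter) and so also has no readable effect, and no measurement at hand offers a reason for either result.

Going by these compounds, whether an ethoxy group or an amine on this aromatic carbon would move the read-out beyond the scatter remains open. Also open, on these data alone, is whether methoxy and hydroxy would separate at a higher concentration.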